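A urea series probed at the vasopressin receptor

This account rests on a few compounds, and the source may have more. Where it says the series, first, only, none or still open, it means among the compounds named here.

Compound 1 `Cc1cc(C(=O)N2CCCCc3ccccc32)ccc1CNC(=O)Nc1ccccc1` carries a phenyl on an amide-type nitrogen of its urea. In a functional assay on HEK293 cells for agonist activity at Vasopressin V2 receptor (Homo sapiens), read by a luciferase reporter and cAMP accumulation (on this read-out lower numbers stand for an effect already at smaller amounts and higher numbers for an effect only at larger amounts of compound), compound 1 gives 130 nM, the highest of the three numbers measured; compound 3 `Cc1cc(C(=O)N2CCCCc3ccccc32)ccc1CNC(=O)NCC(=O)N1CCCC1` comes nearest with 100 nM, and compound 2 `COC(=O)CNC(=O)NCc1ccc(C(=O)N2CCCCc3ccccc32)cc1C` lies furthest with 37 nM. Both neighbours replace the phenyl with a small carbonyl-bearing chain: the step of a 3.5-fold lower number from compound 1 to compound 2 (0.55 log units; beyond the scatter), while the step of a 1.3-fold lower number from compound 1 to compound 3 (0.11 log units; within the scatter). Between the two chains, the step of a 2.7-fold higher number from compound 2 to compound 3 (0.43 log units; beyond the scatter).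

Compound 4 `Cc1cc(C(=O)N2CCCCc3ccccc32)ccc1CNC(=O)N1CCC[C@H]1C(=O)O` takes the change one stage further: 2-carboxypyrrolidin-1-yl in place of anilino on a carbonyl carbon, so the urea nitrogen itself becomes part of a five-membered ring that bears a carboxylic acid. Going by the values given here, no measured step covers exactly this change, but the two steps from compound 1 show that removing the phenyl in favour of a small oxygen-bearing group has either left the number within the scatter or lowered it modestly. A similar outcome is expected here, with the direction uncertain. Compound 4 is therefore estimated at 70 nM in this assay, within 25 nM to 200 nM, a step of a 1.9-fold lower number from compound 1 to compound 4 (0.27 log units; within the scatter) expected.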

Compound 4, half-maximal effective concentration: 680 nM
Beside the measured number, compound 4's estimate is 9.7-fold (0.99 log units) below it; the whole stated range lies below it.
By their numbers in this assay, from the lowest: compound 2; then compounds 3 and 1 (each within the scatter of the next); then compound 4.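

In this assay, the change at this carbonyl carbon now runs the other way: 2-carboxypyrrolidin-1-yl in place of anilino gives a 5.2-fold higher number from compound 1 to compound 4 (0.72 log units; beyond the scatter), whereas the two earlier replacements of the phenyl left the number within the scatter or lowered it. The contrast is sharper against the two open-chain ureas, with a 6.8-fold higher number from compound 3 to compound 4 (0.83 log units; beyond the scatter) and, the largest step in this set, an 18-fold higher number from compound 2 to compound 4 (1.26 log units; beyond the scatter), so a small carbonyl-bearing group at this place does not by itself keep the number low. No measurement shown here bears on what lies behind this rise.

Compound 4 brings in the five-membered ring and the carboxylic acid together, so the compounds shown do not say which of the two goes with the higher number; a plain pyrrolidin-1-yl, the methyl ester of the 2-carboxypyrrolidin-1-yl group or an open-chain carboxymethylamino group on this carbonyl carbon would separate them. From the compounds shown here alone, the opposite configuration at the defined stereocentre of the 2-carboxypyrrolidin-1-yl group also remains open.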